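Swapping Chloro for Nitro on a Quinazoline Urea Series

The compounds below may be only part of what the source reports. "The series", "measured", "known", "first", "only" and "open" are said of these compounds alone.

Compound 1 `COc1cc2ncnc(NCc3cccc(NC(=O)Nc4ccccc4)c3)c2cc1OC` carries a phenylurea attached to the shared core; in a functional assay on HepG2 cells (Homo sapiens) for antiproliferative activity, read by MTT assay (a higher number here means a weaker inhibitor, a lower number a stronger inhibitor), compound 1 gives 19700 nM. Compound 2 `COc1ccccc1NC(=O)Nc1cccc(CNc2ncnc3cc(OC)c(OC)cc23)c1` adds a methoxy group to the outer phenyl ring, and in this assay compound 2 gives 27200 nM; the step of a 1.4-fold higher number from compound 1 to compound 2 (0.14 log units; within the scatter) stays inside the usual scatter. Compound 3 `COc1cc2ncnc(NCc3cccc(NC(=O)Nc4ccc(Cl)cc4)c3)c2cc1OC` instead carries a chloro group on that ring. For compound 3 this assay reports only a limit, > 50000 nM. Against compound 1 this is a weakening, an at least 2.5-fold higher number from compound 1 to compound 3 (0.40 log units; beyond the scatter), while against compound 2 the step of an at least 1.8-fold higher number from compound 2 to compound 3 (0.26 log units; that floor lies within the scatter) has a floor that still lies within the scatter. Compound 3 therefore stands at the ceiling of the assay, (the limit of > 50000 nM in this assay, at which 1 of the 3 values shown sits).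

Compound 4 `COc1cc2ncnc(NCc3cccc(NC(=O)Nc4ccc([N+](=O)[O-])cc4)c3)c2cc1OC` is the next step: nitro in place of chloro on an aromatic carbon. Within the data shown here, none of the measured steps exchanges one substituent for another at this position, so the only guidance is indirect: adding chloro here carried compound 3 to the limit, whereas adding methoxy left compound 2 close to compound 1. Among the measured compounds shown here, with no direct precedent, compound 4 is expected to remain a weak inhibitor in this assay, the step of a number no higher from compound 3 to compound 4 (the limit leaves the size open) being expected to show essentially no change. The estimate for compound 4 in this assay is 50000 nM, with a range from 15000 nM to 150000 nM.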

Compound 4, half-maximal inhibitory concentration: 18800 nM
Beside the measured number, compound 4's estimate is 2.7-fold (0.42 log units) above it; the measured number falls inside the stated range.
By their numbers in this assay, from the lowest: compounds 4, 1 and 2 (each within the scatter of the next). At a limit, above all of these: compound 3.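

In this assay, the weak result of compound 3 turns out to belong to chloro rather than to any group at this position, since nitro in place of chloro gives an at least 2.6-fold lower number from compound 3 to compound 4 (0.42 log units; beyond the scatter). Nitro at this position leaves the number no different from that of the unsubstituted phenyl ring, with a 1.0-fold lower number from compound 1 to compound 4 (0.02 log units; within the scatter), and the comparison with the 2-methoxyphenyl urea reads the same way, with a 1.4-fold lower number from compound 2 to compound 4 (0.16 log units; within the scatter). The chloro-to-nitro step can only be given as a floor because compound 3 sits at a limit: the limit of > 50000 nM in this assay, at which 1 of the 4 values shown sits.

The compounds shown place only chloro and nitro at this position, and these two groups give different outcomes, so no general rule for the position can be drawn from them. As far as these compounds go, it remains open whether an amine, a carboxylic acid or a methyl ester here would stay level with compound 1, fall to the limit seen for chloro, or give a number clearly lower than any of those seen so far.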